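Propyl on the Unsubstituted Ring of a Diacylhydrazine

The source may hold more compounds than are shown below. What is called first, only, known or untested is meant among the compounds shown, and "the series" means these compounds.

Measured compounds:
compound 1 `CC(C)(C)N(NC(=O)c1ccccc1)C(=O)c1ccccc1Cl`, 75.9 nM
compound 2 `CC(C)(C)N(NC(=O)c1ccccc1)C(=O)c1ccccc1Br`, 170 nM
compound 3 `CCc1ccccc1C(=O)N(NC(=O)c1ccccc1)C(C)(C)C`, 589 nM

The three compounds were tested in an assay on cells for agonist activity at ecdysone receptor (Bombyx mori), read by a luciferase reporter, with a stated time of 24 h; on this read-out lower numbers stand for an effect already at smaller amounts and higher numbers for an effect only at larger amounts of compound. Compound 1 gives the lowest number of the three: the step of a 2.2-fold higher number from compound 1 to compound 2 (0.35 log units; beyond the scatter) and the step of a 7.8-fold higher number from compound 1 to compound 3 (0.89 log units; beyond the scatter) both run upward from it, as does the step of a 3.5-fold higher number from compound 2 to compound 3 (0.54 log units; beyond the scatter). All three measured steps concern the group on the aromatic carbon of the chlorinated ring.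

Compound 4 `CCCc1ccc(C(=O)NN(C(=O)c2ccccc2Cl)C(C)(C)C)cc1` has not been measured. The change from compound 1 is propyl in place of hydrogen on an aromatic carbon, the new group sitting on a six-membered aromatic ring of carbon only, para to a large group, on the ring that carries no substituent in compound 1. Among the measured compounds shown here, none of the measured steps alters this ring, so no measured step bears directly on the change; the data give no handle on how this assay responds to a group in that place.

For the measured compounds named here, with no step to lean on, compound 4 is estimated to give about 50 nM, within a range from 8 nM to 300 nM, which is the expected step of a 1.5-fold lower number from compound 1 to compound 4 (0.18 log units; within the scatter).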

Compound 4, half-maximal effective concentration: 9.12 nM
Compound 4: the middle estimate sits 5.5-fold (0.74 log units) above what was measured; low and high end bracket the measured number.
By their numbers in this assay, from the lowest: compound 4; then compound 1; then compound 2; then compound 3.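

In this assay the entering propyl, on an aromatic carbon of a six-membered aromatic ring of carbon only and para to a large group, gives an 8.3-fold lower number from compound 1 to compound 4 (0.92 log units; beyond the scatter). This is the first step shown that runs downward from compound 1, whose number had been the lowest of the earlier compounds, and it shows that this place accepts a chain and that the number responds to a change there, which the steps among compound 1, compound 2 and compound 3 could not show. Nothing available explains why the number falls with this change.

Propyl is the only group shown at this place, so it remains open whether a shorter chain such as methyl, a longer chain such as butyl, or a group such as an amine or a carboxylic acid would move the number in the same direction or by a similar amount. From the compounds shown here alone, it also remains open whether propyl would give a similar step if bromo or ethyl stood in place of the chloro of compound 4.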